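This account rests on a few compounds, and the source may have more. Where it says the series, first, only, none or still open, it means among the compounds named here.

Compound 1 `CC[C@H](C)[C@H](NC(=O)c1cccc(Cn2ccnc2)c1)C(=O)NNS(=O)(=O)c1ccc(C)cc1`: 20%
Compound 2 `CC[C@H](C)[C@H](NC(=O)c1cccc(Cn2ccnc2)c1)C(=O)NNS(=O)(=O)c1ccc(OC)cc1`: 20%

In an assay on HEK293 cells for displacement of a labelled ligand from Type-2 angiotensin II receptor (Homo sapiens), tested at 10 uM (on this read-out lower numbers stand for a weaker effect and higher numbers for a stronger effect at the one concentration tested), compound 2 gives 20% and stands level with compound 1, which gives 20% in this assay. Within the data shown here, the only measured step, no change at the digits printed from compound 1 to compound 2 (within the scatter), is within the scatter. Compound 3 `CC[C@H](C)[C@H](NC(=O)c1cccc(Cn2ccnc2)c1)C(=O)NNS(=O)(=O)c1c(C)cc(C)cc1C` differs from compound 2 by 2,4,6-trimethylphenyl in place of 4-methoxyphenyl on a sulfonyl sulfur. Among the measured compounds shown here, no measured step bears directly on this change, since the one known step swaps a methyl for a methoxy on the same aromatic carbon while leaving the ring otherwise bare, whereas compound 3 carries three methyls on that ring. Given that the single measured change on this ring produced no shift, the step of no change at the digits printed from compound 2 to compound 3 (within the scatter) is expected to stay small as well, with no direction claimed beyond the scatter. Compound 3 is therefore estimated to give 20%, with a range from 5% to 40% in this assay.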

Compound 3, a percentage reported as inhibition, at one concentration (the size of the read-out at that concentration, not a potency): 27%
Beside the measured number, compound 3's estimate is 7 percentage points below it; measured number inside the range.
By their numbers in this assay, from the lowest: compounds 1, 2 and 3 (each within the scatter of the next).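

In this assay, 2,4,6-trimethylphenyl on the sulfonyl sulfur gives a number 7 percentage points higher from compound 2 to compound 3 (within the scatter) against 4-methoxyphenyl and a number 7 percentage points higher from compound 1 to compound 3 (within the scatter) against 4-methylphenyl. Among these compounds, the earlier pair tested only one group exchanged on this ring, whereas these steps show that a ring carrying three methyl groups also leaves the read-out within the scatter of both earlier compounds, so all three aryl groups on the sulfonyl sulfur remain indistinguishable here. Nothing shown gives a reason for this result.

From the compounds shown here alone, whether a phenyl ring bearing a carboxylic acid or an amine, or a longer alkyl chain in place of the ring, would move the read-out beyond the scatter stays open. So does whether changes elsewhere on the shared core would matter more than those at the sulfonyl sulfur.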